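Compound 4: replacing the 4-methylphenyl group

The source may hold more compounds than are shown below. What is called first, only, known or untested is meant among the compounds shown, and "the series" means these compounds.

Measured in an ADME assay on H9c2 cells (Rattus norvegicus) for cytotoxicity, read by MTT assay, with a stated time of 48 h; a lower number here means a stronger inhibitor, a higher number a weaker inhibitor:
- compound 1 `CC(C)(Oc1ccc(Cl)cc1)C(=O)NCCOC(=S)Nc1ccc(F)cc1`: > 800000 nM, a limit of the assay
- compound 2 `COc1ccc(NC(=S)OCCNC(=O)C(C)(C)Oc2ccc(Cl)cc2)cc1`: 747000 nM
- compound 3 `Cc1ccc(NC(=S)OCCNC(=O)C(C)(C)Oc2ccc(Cl)cc2)cc1`: 771000 nM

Within the data shown here, compound 3 stands level with compound 2, and the only step between two true numbers is a 1.0-fold higher number from compound 2 to compound 3 (0.01 log units; within the scatter). The two steps out of compound 1 are floors only, because of the limit of > 800000 nM in this assay, at which 1 of the 3 values shown sits. They are an at least 1.0-fold lower number from compound 1 to compound 2 (0.02 log units; that floor lies within the scatter) and an at least 1.0-fold lower number from compound 1 to compound 3 (0.01 log units; that floor lies within the scatter).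

Compound 4 `CC(C)(Oc1ccc(Cl)cc1)C(=O)NCCOC(=S)Nc1ccc([N+](=O)[O-])cc1Cl` departs from compound 3 by a larger change: 2-chloro-4-nitrophenyl in place of 4-methylphenyl on an amide-type nitrogen. Among the measured compounds shown here, it puts 2-chloro-4-nitrophenyl in place of 4-methylphenyl on an amide-type nitrogen, a group that no measured compound carries. All three measured steps are single swaps on the aromatic ring, and none goes beyond the scatter, so they give no direction. Only a modest move towards a lower number in this assay is therefore expected, as an allowance for the untested group. The estimated step is a 1.3-fold lower number from compound 3 to compound 4 (0.11 log units; within the scatter). The expected value for compound 4 is 600000 nM, within an estimated range of 250000 nM to 800000 nM.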

Compound 4, half-maximal inhibitory concentration: > 800000 nM
Compound 4 ended at the assay's limit; the forecaster's own chance of this, stated with the estimate: 35%; middle value at least 1.3-fold (0.12 log units) from the limit.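

In this assay compound 4 gives > 800000 nM, which is a limit of the assay and not a number. On the amide-type nitrogen, the 2-chloro-4-nitrophenyl group gives an at least 1.0-fold higher number from compound 3 to compound 4 (0.01 log units; that floor lies within the scatter) and an at least 1.0-fold higher number from compound 2 to compound 4 (0.02 log units; that floor lies within the scatter), so this larger change, unlike the earlier single swaps on the aromatic ring, brings in two hydrogen-bond acceptors and still shows no move beyond the scatter. These two steps are floors only and the step between compound 1 and compound 4 cannot be read, because of the ceiling of the assay: the limit of > 800000 nM in this assay, at which 2 of the 4 values shown sit.

As far as these compounds go, how far compound 1 and compound 4 lie past that limit remains open, as does what the chloro and the nitro each contribute alone. From the compounds shown here alone, whether an amine or a carboxylic acid on the aromatic ring would bring the number down into the measurable range is also open.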